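The source may hold more compounds than are shown below. What is called first, only, known or untested is meant among the compounds shown, and "the series" means these compounds.

Measured in an ADME assay on the whole organism (strain Sprague-Dawley) for pharmacokinetics, with Rattus norvegicus as the target, read by LC-MS, at a dose of 50 mg/kg by the oral route; a higher number here means that a larger share of the oral dose reaches the circulation, a lower number that a smaller share of the oral dose reaches the circulation:
- compound 1 `CCOC(=O)C1=C[C@@H](OC(CC)CC)[C@H](NC(C)=O)[C@@H](N/C(C)=N/O)C1`: 31.4%
- compound 2 `CCOC(=O)C1=C[C@@H](OC(CC)CC)[C@H](NC(C)=O)[C@@H](N/C(N)=N\O)C1`: 1.5%

Compound 2 holds the lower of the two numbers in this assay. Compound 3 `CCOC(=O)C1=C[C@@H](OC(CC)CC)[C@H](NC(C)=O)[C@@H](NC(C)=N)C1` differs from it by a group of 3 heavy atoms (2 carbon, 1 nitrogen; no ring) in place of a group of 4 heavy atoms (1 carbon, 2 nitrogen, 1 oxygen; no ring), on an amine nitrogen. Within the data shown here, one measured step bears on this change at the same amine nitrogen: a number 29.9 percentage points lower from compound 1 to compound 2 (beyond the scatter). That step shows that this site can matter, but neither measured compound carries the entering group. Only a small rise is therefore expected, because compound 2 sits at 1.5%. The expected change is a number 6.5 percentage points higher from compound 2 to compound 3 (within the scatter), with no shift beyond the scatter anticipated. For compound 3 the estimate is 8%, with an expected range of 1% to 25%.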

Compound 3, oral bioavailability in the Rattus norvegicus assay: 0.8%
Beside the measured number, compound 3's estimate is 7.2 percentage points above it; measured number outside the range, below it.
By their numbers in the Rattus norvegicus assay, from the lowest: compounds 3 and 2 (each within the scatter of the next); then compound 1.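

In the Rattus norvegicus assay the step is a number 0.7 percentage points lower from compound 2 to compound 3 (within the scatter), so the two groups on the amine nitrogen cannot be told apart in this read-out. In the Rattus norvegicus assay the comparison with compound 1 gives a number 30.6 percentage points lower from compound 1 to compound 3 (beyond the scatter), so two different groups at this site now sit well under compound 1, and its group alone keeps the higher number. In a physicochemical assay for solubility, read by HPLC, in phosphate buffer, with a stated time of 20 min, at pH 9.0 (a higher number here means a more soluble compound, a lower number a less soluble compound), compound 2 gives > 50000000 nM and this is a limit of the assay, not a number. In the physicochemical assay compound 3 gives > 50000000 nM and this too is a limit of the assay, not a number. In the physicochemical assay the step from compound 2 to compound 3 cannot be read, as both values are limits: the limit of > 50000000 nM in the physicochemical assay, at which 2 of the 2 values shown sit.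

The compounds shown leave open whether a longer chain on the same amine nitrogen would stay near compound 1 or near compound 2 and compound 3.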